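The source may report more compounds than this note shows. Statements on the series, on what has been measured and on what is new or still open speak of the compounds shown alone.

Measured compounds:

compound 1 `O=C(NNc1nc(-c2ccccc2)c[se]1)c1ccccc1` — this value is a limit: > 73000 nM
compound 2 `O=C(NNc1nc(-c2ccccc2)c[se]1)c1ccc(Cl)cc1` — 62900 nM
compound 3 `CC(=O)N(C(=O)c1ccccc1)N(C(C)=O)c1nc(C)c[se]1` — this value is a limit: > 68600 nM

In a functional assay on HepG2 cells (Homo sapiens) for cytotoxicity, read by XTT assay, with a stated time of 72 h (on this read-out higher numbers stand for weaker inhibition and lower numbers for stronger inhibition), compound 1 sits at a limit, (the limit of > 73000 nM in this assay, at which 1 of the 3 values shown sits). Compound 2 carries the change chloro in place of hydrogen on an aromatic carbon and gives an at least 1.1-fold lower number from compound 1 to compound 2 (0.06 log units; that floor lies within the scatter). Compound 3 also sits at a limit, (the limit of > 68600 nM in this assay, at which 1 of the 3 values shown sits); the difference between the core of compound 3 and the core of compound 1 is not broken down here.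

Compound 4 `CC(=O)N(C(=O)c1ccc(Cl)cc1)N(C(C)=O)c1nc(C)c[se]1` is not yet measured. It carries the change (chloro in place of hydrogen on an aromatic carbon), the same change as from compound 1 to compound 2, at the same place. In this assay the expected step is an at least 1.0-fold lower number from compound 3 to compound 4 (0.02 log units; that floor lies within the scatter), resting on the small step seen with an at least 1.1-fold lower number from compound 1 to compound 2 (0.06 log units; that floor lies within the scatter) and on compound 3 giving only a limit, > 68600 nM. The expected value for compound 4 is 65000 nM, between 35000 nM and 120000 nM, with a real chance that only a limit is reported.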

Compound 4, half-maximal inhibitory concentration: > 62700 nM
Compound 4 ended at the assay's limit; the forecaster's own chance of this, stated with the estimate: 55%; the middle value lies beyond the limit too.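

In this assay compound 3 gives only a limit, > 68600 nM. Among the compounds shown here, compound 4 also gives only a limit, > 62700 nM, so no step between these two compounds can be read. The compounds shown leave open whether phenyl to 4-chlorophenyl changes the read-out on the core of compound 3.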